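Swapping thiomorpholine for morpholine on a thiosemicarbazone

The compounds below may be only part of what the source reports. "The series", "measured", "known", "first", "only" and "open" are said of these compounds alone.

Of the compounds shown here, three have been measured in a functional assay on A-375 cells (Homo sapiens) for cytotoxicity, read by MTT assay, with a stated time of 72 h, tested at 3 uM; a lower number here means less inhibition of growth, a higher number more inhibition of growth at the concentration tested. Compound 1 `N/C(=N\NC(=S)N1CCOCC1)c1ccccn1` gives 19.3%, compound 2 `N/C(=N\NC(=S)N1CCCC1)c1ccc(F)cn1` gives 81.8%, and compound 3 `N/C(=N\NC(=S)N1CCSCC1)c1ccc(F)cn1` gives 62.2%. Compound 3 thus stands second of the three, with compound 2 beyond the scatter higher and compound 1 well lower. For the measured compounds named here, the one measured step within this set, a number 19.6 percentage points lower from compound 2 to compound 3 (beyond the scatter), shows a modest loss.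

Compound 4 `N/C(=N\NC(=S)N1CCOCC1)c1ccc(F)cn1` differs from compound 3 by morpholin-4-yl in place of thiomorpholin-4-yl on a thiocarbonyl carbon. Going by the values given here, no measured step carries this exact change, so the expectation rests on indirect reading: compound 1, which also bears morpholin-4-yl on a thiocarbonyl carbon but on a different core, sits at the bottom of the range, and the step from compound 2 to compound 3 already moved downward when the five-membered ring gave way to a six-membered one. A further drop beyond the scatter is therefore expected, a number 22.2 percentage points lower from compound 3 to compound 4 (beyond the scatter), though its size is uncertain. Compound 4 is estimated at 40%, within a range from 15% to 65%.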

Compound 4, percent growth inhibition at one concentration: 66.4%
For compound 4 the middle estimate is 26.4 percentage points below the measured one; the measured number lies above the stated range.
By their numbers in this assay, from the lowest: compound 1; then compounds 3 and 4 (each within the scatter of the next); then compound 2.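

In this assay, morpholin-4-yl in place of thiomorpholin-4-yl on a thiocarbonyl carbon gives a number 4.2 percentage points higher from compound 3 to compound 4 (within the scatter) on the shared core, so this exchange of one ring hetero atom for another does not separate the two compounds. Morpholin-4-yl, like thiomorpholin-4-yl, stays under pyrrolidin-1-yl, with a number 15.4 percentage points lower from compound 2 to compound 4 (beyond the scatter) in this assay. Morpholin-4-yl alone therefore does not set the low place of compound 1: with that group held constant, fluoro in place of hydrogen on an aromatic carbon gives a number 47.1 percentage points higher from compound 1 to compound 4 (beyond the scatter), the largest step in the set, and no measurement at hand accounts for any of these steps.

As far as these compounds go, whether fluoro brings a similar step with pyrrolidin-1-yl or thiomorpholin-4-yl remains open. So does the effect of piperidin-1-yl, piperazin-1-yl or an open-chain dimethylamino group on the thiocarbonyl carbon.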